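The compounds below may be only part of what the source reports. "The series", "measured", "known", "first", "only" and "open" are said of these compounds alone.

Compound 1 (`O=C(CSc1ccccc1)N1N=C(c2cc3ccccc3oc2=O)C[C@@H]1c1ccccc1`) and compound 2 (`O=C(CSc1ccc(Br)cc1)N1N=C(c2cc3ccccc3oc2=O)C[C@@H]1c1ccccc1`) share the same core and have both been tested in a functional assay on SGC-7901 cells (Homo sapiens) for cytotoxicity, read by MTT assay, with a stated time of 48 h; on this read-out lower numbers stand for stronger inhibition and higher numbers for weaker inhibition. In that test compound 1 gives 20300 nM and compound 2 gives 14300 nM, which places compound 2 level with compound 1, within the scatter of repeated measurements. Compound 3 (`CCCCSCC(=O)N1N=C(c2cc3ccccc3oc2=O)C[C@@H]1c1ccccc1`) has not yet been measured. It differs from compound 2 as follows: butyl in place of 4-bromophenyl on a sulfur. In words, this is butyl in place of 4-bromophenyl on a sulfur. Within the data shown here, only one measured step offers any guide, a 1.4-fold lower number from compound 1 to compound 2 (0.15 log units; within the scatter), which is bromo in place of hydrogen on an aromatic carbon. Among the measured compounds shown here, that step keeps the aromatic ring on the sulfur, whereas the change to compound 3 removes it, and no measured compound carries a chain there. The evidence is therefore indirect, and no step beyond the scatter is expected in this assay, although a somewhat higher number seems the likelier direction. The estimated step is a 1.5-fold higher number from compound 2 to compound 3 (0.19 log units; within the scatter). For compound 3 the expected value is 22000 nM, with an estimated range from 10000 nM to 50000 nM.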

Compound 3, half-maximal inhibitory concentration: 7300 nM
Estimate against measurement, compound 3: 3.0-fold (0.48 log units) above; measured number outside the range, below it.
By their numbers in this assay, from the lowest: compounds 3, 2 and 1 (each within the scatter of the next, the first and the last beyond it).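

In this assay the result shows that this sulfur does not need an aromatic ring: butyl, which carries no ring, gives a 2.8-fold lower number from compound 1 to compound 3 (0.44 log units; beyond the scatter) when it takes the place of phenyl, and this is the only step among these compounds that lies beyond the scatter, though it is a modest one. Set against 4-bromophenyl, the same butyl group gives a 2.0-fold lower number from compound 2 to compound 3 (0.29 log units; within the scatter) and so stays within the scatter, which means that the chain matches the brominated ring on this sulfur but cannot be ranked ahead of it. No measurement at hand accounts for how a saturated chain compares with these aromatic groups.

The compounds shown leave open whether butyl is a particular fit or whether a shorter chain such as ethyl, a longer chain such as octyl, or a branched group such as isobutyl would give a similar number. They also do not say how a hydroxyl, an amine or a carboxylic acid at the end of the butyl chain would read in this test.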